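Replacing an anilide with a morpholine amide

The source may report more compounds than this note shows. Statements on the series, on what has been measured and on what is new or still open speak of the compounds shown alone.

Compound 1 `O=C(CCC(=O)OCCCCCCSc1ccc([N+](=O)[O-])c2nonc12)Nc1ccccc1`: 2120 nM
Compound 2 `COc1ccccc1NC(=O)CCC(=O)OCCCCCCSc1ccc([N+](=O)[O-])c2nonc12`: 2850 nM

In a functional assay on HOS cells (Homo sapiens) for inhibition, read by MTT assay, with a stated time of 72 h (a lower number here means a stronger inhibitor, a higher number a weaker inhibitor), compound 1 gives 2120 nM and compound 2 gives 2850 nM. Among the measured compounds shown here, compound 2 sits alongside compound 1 rather than apart from it, since the only measured step, a 1.3-fold higher number from compound 1 to compound 2 (0.13 log units; within the scatter), lies within the scatter.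

Compound 3 `O=C(CCC(=O)N1CCOCC1)OCCCCCCSc1ccc([N+](=O)[O-])c2nonc12` changes a different part of the molecule: morpholin-4-yl in place of (2-methoxyphenyl)amino on a carbonyl carbon. For the measured compounds named here, the one measured step concerned a methoxy on the aromatic ring that now leaves, and it was too small to show any effect; no measured step touches the amide itself. There is thus no basis for expecting a shift in either direction, only added uncertainty. Compound 3 is expected to land close to compound 2, with the expected shift a 1.1-fold lower number from compound 2 to compound 3 (0.04 log units; within the scatter) inside the scatter. Compound 3 is estimated at 2600 nM, with a range from 900 nM to 8000 nM.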

Compound 3, half-maximal inhibitory concentration: 1010 nM
Compound 3: middle estimate off by 2.6-fold (0.41 log units), on the high side; the range from low to high includes it.
By their numbers in this assay, from the lowest: compound 3; then compounds 1 and 2 (each within the scatter of the next).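

The group on this carbonyl carbon can move the number in this assay, which the small methoxy change on the aromatic ring could not show. Morpholin-4-yl in place of (2-methoxyphenyl)amino gives a 2.8-fold lower number from compound 2 to compound 3 (0.45 log units; beyond the scatter), and morpholin-4-yl in place of anilino gives a 2.1-fold lower number from compound 1 to compound 3 (0.32 log units; beyond the scatter), so both steps are modest but beyond the scatter and point the same way. Nothing measured here explains this shift.

This swap removes the aromatic ring and the amide hydrogen together and brings in a ring with a second hetero atom, so the compounds shown cannot say which of these changes matters. From the compounds shown here alone, it also remains open how a piperidin-1-yl or a dimethylamino group on the same carbonyl carbon would compare with morpholin-4-yl.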